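Methyl to methoxy on an unmeasured flavone

The compounds below may be only part of what the source reports. "The series", "measured", "known", "first", "only" and "open" are said of these compounds alone.

Compound 2, `COc1cccc(/C=C/C(=O)c2ccc(OCC(=O)Nc3ccc(OC)c(OC)c3)cc2)c1`, in an ADME assay on MDCK-II cells (Canis lupus familiaris) for inhibition, read by MTT assay, with a stated time of 72 h; a lower number here means a stronger inhibitor of growth, a higher number a weaker inhibitor of growth: 33200 nM.
Compound 3, `CCCOc1ccc(/C=C/C(=O)c2ccc(O)cc2)cc1`, in this assay: 31100 nM.
Compound 1, `Cc1ccc(-c2c(OCC(=O)Nc3cccc4ccccc34)oc3ccccc3c2=O)cc1`, in this assay: "not determined" (no result reported).

Compound 1 stands nowhere on the numbers shown: it carries no value in this assay, so the step to compound 4, `COc1ccc(-c2c(OCC(=O)Nc3cccc4ccccc34)oc3ccccc3c2=O)cc1`, cannot be anchored on it. The change is methoxy in place of methyl on an aromatic carbon. No step between measured compounds is shown, and compound 2 and compound 3 sit within the scatter of each other, so no size of step in this assay is known from the data; the step from compound 1 to compound 4 is expected to be small, likely none beyond the scatter. Because compound 2 gives 33200 nM and compound 3 gives 31100 nM, compound 4 is estimated at 30000 nM, expected between 10000 nM and 100000 nM.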

Compound 4, concentration for 50% growth inhibition: > 100000 nM
Compound 4: no number, only a limit; the forecaster's own chance of this, stated with the estimate: 30%; middle value at least 3.3-fold (0.52 log units) away from the limit.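

No step can be read from compound 1 to compound 4: compound 1 carries no result in this assay. Compound 4 gives > 100000 nM, which is a limit and not a number. On these data alone, what the change from 4-methylphenyl to 4-methoxyphenyl does in this assay stays open.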